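From 3,4-dimethylphenyl to 2,6-dimethoxyphenyl on a shared core

A few compounds are considered here, and "the series" means these few. Any claim that something is new, unique, unknown or untested is made for them only; others in the source may bear on it.

In an ADME assay on microsomes from liver (Rattus norvegicus) for metabolic stability, read by LC-MS, using NADPH, at 37 degrees C (on this read-out higher numbers stand for a longer-lived compound and lower numbers for a shorter-lived compound), compound 1 `Cc1oc(-c2ccc(F)cc2)nc1CN1CCC(C(=O)NCCCN2C[C@H](C)C[C@H](C)C2)CC1`, which carries 4-fluorophenyl, gives 0.468 h. Compound 2 `Cc1oc(-c2c(Cl)cccc2Cl)nc1CN1CCC(C(=O)NCCCN2C[C@H](C)C[C@H](C)C2)CC1`, which carries 2,6-dichlorophenyl, gives 0.0483 h. Compound 3 `Cc1ccc(-c2nc(CN3CCC(C(=O)NCCCN4C[C@H](C)C[C@H](C)C4)CC3)c(C)o2)cc1C`, which carries 3,4-dimethylphenyl, gives > 0.5 h, and this is a limit of the assay, not a number. Compound 4 `COc1cccc(OC)c1-c1nc(CN2CCC(C(=O)NCCCN3C[C@H](C)C[C@H](C)C3)CC2)c(C)o1` is still unmeasured: it has 2,6-dimethoxyphenyl in place of 3,4-dimethylphenyl on an aromatic carbon.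

The measured steps offer a guide. Exchanging 4-fluorophenyl for 3,4-dimethylphenyl gave an at least 1.0-fold higher number from compound 1 to compound 3 (0.02 log units; that floor lies within the scatter). Moving to 2,6-dichlorophenyl gave a 9.7-fold lower number from compound 1 to compound 2 (0.99 log units; beyond the scatter), a modest step, and leaving that group gave an at least 10-fold higher number from compound 2 to compound 3 (1.01 log units; beyond the scatter), a large one. The group in compound 2 is the measured one closest in name to 2,6-dimethoxyphenyl, so a fall beyond the scatter is expected in this assay, though this rests on compound 2 alone. The estimated change is an at least 4.1-fold lower number from compound 3 to compound 4 (0.61 log units; beyond the scatter). For compound 4 the estimate is 0.12 h, with an expected range from 0.04 h to 0.45 h.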

Compound 4, half-life: 0.2 h
The estimate for compound 4 lay 1.7-fold (0.22 log units) below the measured number, and the stated range covers the measured number.
By their numbers in this assay, from the lowest: compound 2; then compound 4; then compound 1. At a limit, above all of these: compound 3.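

In this assay, the new result shows that 2,6-dimethoxyphenyl and 2,6-dichlorophenyl do not behave alike at this position: 2,6-dimethoxyphenyl in place of 2,6-dichlorophenyl gives a 4.1-fold higher number from compound 2 to compound 4 (0.62 log units; beyond the scatter). Even so, 2,6-dimethoxyphenyl and 2,6-dichlorophenyl both read lower than the other two groups, as 2,6-dimethoxyphenyl still gives a 2.3-fold lower number from compound 1 to compound 4 (0.37 log units; beyond the scatter) and also an at least 2.5-fold lower number from compound 3 to compound 4 (0.39 log units; beyond the scatter). That last step is only a floor, as compound 3 stands at a limit of the assay and not at a number: the limit of > 0.5 h in this assay, at which 1 of the 4 values shown sits.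

The compounds shown leave open how a phenyl ring with a single methoxy group, or with no added group at all, would read at this position. They also leave open whether a pyridine ring in place of the phenyl ring would keep the longer half-life.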